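Title: From (Methylsulfonyl)oxy to (6-Aminohexyl)amino on One Core

This account rests on a few compounds, and the source may have more. Where it says the series, first, only, none or still open, it means among the compounds named here.

Measured so far in a functional assay on HCT-116 cells (Homo sapiens) for cytotoxicity, read by MTT assay, with a stated time of 72 h; on this read-out higher numbers stand for weaker inhibition and lower numbers for stronger inhibition:
compound 1 `CS(=O)(=O)Oc1c(C(=O)NCc2ccc(F)cc2)nc(Br)c2cccnc12` gives > 20000 nM
compound 2 `N[C@H]1CC[C@H](Nc2c(C(=O)NCc3cccc(C(F)(F)F)c3)nc(Br)c3cccnc23)CC1` gives "not determined" (no result reported)
compound 3 `NCCCCCCNc1c(C(=O)NCc2ccc(F)cc2)nc(Br)c2cccnc12` is still to be measured

For compound 1 the entry > 20000 nM is a limit of the assay rather than a number. Among the compounds with values here, compound 1 therefore stands at the limit of > 20000 nM in this assay, at which 1 of the 2 values shown sits, and compound 2 adds no number at all, so no step between measured compounds can be drawn and nothing shows how changes at this position move the read-out.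

The change from compound 1 to compound 3 is (6-aminohexyl)amino in place of (methylsulfonyl)oxy on an aromatic carbon. A small group with no hydrogen-bond donors gives way to a longer chain with two hydrogen-bond donors, in the words of that description. Since compound 1 already sits at the limit, the only direction a numerical result can take is toward stronger inhibition, though a second limit remains possible.

Compound 3 is expected to come in near 5000 nM, with a likely range from 1000 nM to 20000 nM. The step is estimated as an at least 4.0-fold lower number from compound 1 to compound 3 (0.60 log units; beyond the scatter), toward stronger inhibition, though this rests only on the limit of compound 1 and the size of the change.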

Compound 3, half-maximal inhibitory concentration: 7000 nM
The estimate for compound 3 lay 1.4-fold (0.15 log units) below the measured number; the range from low to high includes it.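

In this assay compound 1 gives > 20000 nM, which is a limit of the assay and not a number. Putting (6-aminohexyl)amino in place of (methylsulfonyl)oxy on this aromatic carbon of the shared core gives an at least 2.8-fold lower number from compound 1 to compound 3 (0.45 log units; beyond the scatter), so a change at this position can move the read-out toward stronger inhibition, and the compounds shown now hold a real number rather than only a limit. The step is a minimum and its full size stays unknown, as its starting point is only a limit: the limit of > 20000 nM in this assay, at which 1 of the 3 values shown sits.

The compounds shown leave open whether the shift goes with the nitrogen attached to the aromatic carbon, with the length of the chain or with the amine at its end, since the whole group changes in a single step. A shorter chain ending in an amine, or a plain hexyl chain with no amine at its end, would help separate these parts, while compound 2 adds nothing here, as it has no reported result and differs from compound 3 in more than one place.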